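This account rests on a few compounds, and the source may have more. Where it says the series, first, only, none or still open, it means among the compounds named here.

Measured so far, shared core, aryl group on the amine nitrogen varied:
compound 1, `CCCc1ccc(NC2=CC(=O)c3c(nc4n3[C@H]3OC[C@@H](O)[C@H]3OC4)C2=O)cc1`, gives 1920 nM
compound 2, `O=C1C=C(Nc2ccccc2)C(=O)c2c1nc1n2[C@H]2OC[C@@H](O)[C@H]2OC1`, gives 1730 nM
compound 3, `O=C1C=C(Nc2ccc(C(F)(F)F)cc2)C(=O)c2c1nc1n2[C@H]2OC[C@@H](O)[C@H]2OC1`, gives 2820 nM

In a functional assay on MGC-803 cells (Homo sapiens) for inhibition, read by sulforhodamine B assay (a lower number here means a stronger inhibitor, a higher number a weaker inhibitor), compound 1 stands second highest of the three numbers; compound 2 is nearest and compound 3 furthest, both within the scatter of compound 1, so the three compounds cannot be ordered. Among the compounds with values here, the one step between measured compounds, a 1.6-fold higher number from compound 2 to compound 3 (0.21 log units; within the scatter), is likewise within the scatter.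

Compound 4, `CCOc1ccccc1NC1=CC(=O)c2c(nc3n2[C@H]2OC[C@@H](O)[C@H]2OC3)C1=O`, differs from compound 1 by 2-ethoxyphenyl in place of 4-propylphenyl on an amine nitrogen. Within the data shown here, the only measured step that bears on a change of the aryl group, a 1.6-fold higher number from compound 2 to compound 3 (0.21 log units; within the scatter), stayed within the scatter, so in this assay no step beyond the scatter is expected in either direction, giving an expected 1.0-fold higher number from compound 1 to compound 4 (0.02 log units; within the scatter). Compound 4 is therefore estimated at 2000 nM, range 900 nM to 4500 nM.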

Compound 4, half-maximal inhibitory concentration: 2830 nM
The estimate for compound 4 lay 1.4-fold (0.15 log units) below the measured number; the range from low to high includes it.
By their numbers in this assay, from the lowest: compounds 2, 1, 3 and 4 (each within the scatter of the next).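

In this assay the change on the amine nitrogen gives a 1.5-fold higher number from compound 1 to compound 4 (0.17 log units; within the scatter) and so stays within the scatter. At this position, neither the hydrogen-bond acceptor entering with 2-ethoxyphenyl nor the different substitution pattern in its name produces a step beyond the scatter. No supporting data on hand give a reason for these numbers.

Still open, on these data alone, is whether an aryl group carrying an amine or a carboxylic acid would leave the scatter. Also open, as far as these compounds go, is whether a longer alkyl chain in place of the aryl group would do so.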